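Acetyl on the ring nitrogen of compound 3

The compounds below may be only part of what the source reports. "The series", "measured", "known", "first", "only" and "open" are said of these compounds alone.

Of the compounds shown here, three sharing one core have been measured in a functional assay on P388 cells (Mus musculus); a higher number here means that more compound is needed for the effect, a lower number that less compound is needed. Compound 1 `O=c1ccn([C@@H]2O[C@H](CO)C[C@@H]2O)c(=O)[nH]1` gives only a limit there, > 100 uM, which is a bound of the assay rather than a number (the limit of > 100 uM in this assay, at which 1 of the 3 values shown sits). Compound 2 `CC(=O)OC[C@@H]1C[C@H](OC(C)=O)[C@H](n2ccc(N)nc2=O)O1` gives 10 uM in this assay. Among the compounds with values here, compound 3 `CC(=O)O[C@H]1C[C@@H](CO)O[C@H]1n1ccc(N)nc1=O` gives 2 uM, the lowest of the two numbers known, with compound 2 as its nearest neighbour. Within the data shown here, the one measured step, a 5.0-fold lower number from compound 2 to compound 3 (0.70 log units; beyond the scatter), shows that taking an acetyl off an oxygen lowers the number beyond the scatter.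

Compound 4 `CC(=O)Nc1ccn([C@@H]2O[C@H](CO)C[C@@H]2OC(C)=O)c(=O)n1` differs from compound 3 by acetyl in place of hydrogen on a nitrogen on an aromatic ring. Among the measured compounds shown here, no measured step touches the ring nitrogen; the only guide is the step of a 5.0-fold lower number from compound 2 to compound 3 (0.70 log units; beyond the scatter), which, read in reverse, suggests that an entering acetyl tends to raise the number. Compound 4 is therefore expected to show a modest rise, a 2.0-fold higher number from compound 3 to compound 4 (0.30 log units; within the scatter), though a change within the scatter would not surprise. The estimate for compound 4 in this assay is 4 uM, with a range from 1 uM to 15 uM.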

Compound 4, concentration for half-maximal effect: > 100 uM
Compound 4 was reported as a limit; the forecaster's own chance of this, stated with the estimate: 5%; middle value at least 25-fold (1.39 log units) from the limit.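

The step on a nitrogen on an aromatic ring is of another order from the one earlier measured on oxygen: amino to acetamido gives an at least 50-fold higher number from compound 3 to compound 4 (1.69 log units; beyond the scatter), whereas acetyl on an oxygen on a saturated carbon accounted for only a 5.0-fold lower number from compound 2 to compound 3 (0.70 log units; beyond the scatter). This single change is enough to take the series from a measured number to the end of the measurable range. In this assay compound 4 gives > 100 uM, which is a limit and not a number, so the step has no known upper end: the limit of > 100 uM in this assay, at which 2 of the 4 values shown sit.

On these data alone, whether any group on this nitrogen raises the number, or acetyl in particular, stays open; a methyl or a longer acyl chain such as butyryl would speak to that. Also open, as far as these compounds go, is whether acetyl on this nitrogen has the same effect when the oxygen on the saturated ring carbon carries hydrogen instead of acetyl.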